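Three weakly cytotoxic compounds and an untested amide

A few compounds are considered here, and "the series" means these few. Any claim that something is new, unique, unknown or untested is made for them only; others in the source may bear on it.

Of the compounds shown here, three have been measured in a functional assay on HCT-116 cells (Homo sapiens) for cytotoxicity, read by resazurin assay, with a stated time of 48 h; on this read-out higher numbers stand for an effect only at larger amounts of compound and lower numbers for an effect already at smaller amounts. Compound 1 `O=C(Nc1ccc(Sc2nc3ccccc3s2)cc1)c1cc(Br)cc(Br)c1O` gives 19000 nM in this assay. Compound 2 `COc1ccc(S(=O)(=O)Nc2ccc3oc(-c4ccc(NS(=O)(=O)c5cc(F)ccc5OC)cc4)nc3c2)cc1` gives 15000 nM in this assay, the second highest of the three numbers; its nearest neighbour is compound 1 and its furthest is compound 3 `COc1ccccc1S(=O)(=O)Nc1ccc(-c2nc3cc(NS(=O)(=O)c4ccccc4OC)ccc3o2)cc1`, which gives 9200 nM in this assay, both gaps lying within the scatter. No pair among these three differs in a single place, so no step between measured compounds can be drawn.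

Compound 4 `COc1ccc(S(=O)(=O)Nc2ccc3oc(-c4ccc(NC(=O)C5CCN(C(C)=O)CC5)cc4)nc3c2)cc1` has not been measured. It differs from compound 2 by a group of 11 heavy atoms (8 carbon, 1 nitrogen, 2 oxygen; one six-membered non-aromatic ring with 1 hetero atom) in place of a group of 12 heavy atoms (7 carbon, 3 oxygen, 1 fluorine, 1 sulfur; one six-membered aromatic ring of carbon only), on a nitrogen on an aromatic ring, the (1-acetylpiperidin-4-yl)carbonyl group standing on a nitrogen on an aromatic ring whose other neighbours are aromatic carbon. For the measured compounds named here, with the three measured values all within the scatter of one another and no single-point step available, no direction can be claimed. The expected step is a 1.2-fold higher number from compound 2 to compound 4 (0.08 log units; within the scatter), taken as none beyond the scatter. Compound 4 is therefore estimated to give 18000 nM in this assay, with a range from 6000 nM to 55000 nM.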

Compound 4, half-maximal effective concentration: 15000 nM
Beside the measured number, compound 4's estimate is 1.2-fold (0.08 log units) above it; measured number inside the range.
By their numbers in this assay, from the lowest: compounds 3, 2, 4 and 1 (each within the scatter of the next, the first and the last beyond it).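

In this assay the exchange on a nitrogen on an aromatic ring gives no change at the digits printed from compound 2 to compound 4 (within the scatter), the first single-place comparison among these compounds. The (1-acetylpiperidin-4-yl)carbonyl group brings a six-membered non-aromatic ring with 1 hetero atom and carries no sulfur or fluorine, yet this read-out does not separate it from the group it replaces, which holds a six-membered aromatic ring of carbon only. Nothing measured here bears on why the two groups read alike.

Going by these compounds, it remains open whether any group at this place can move the number beyond the scatter. A lone acetyl group on that nitrogen, or a group carrying a free amine or a carboxylic acid, could answer this, and the compounds shown do not say how either would read.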